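Chalcone-pyrazole series: aryl ketone swap on compound 3

A few compounds are considered here, and "the series" means these few. Any claim that something is new, unique, unknown or untested is made for them only; others in the source may bear on it.

Three members of the series have numbers in a functional assay on RPMI-8226 cells (Homo sapiens) for cytotoxicity, read by sulforhodamine B assay, with a stated time of 48 h, tested at 10 uM (on this read-out lower numbers stand for a stronger effect and higher numbers for a weaker effect at the one concentration tested), so far. Compound 1 `COc1ccc(-c2cc(/C=C/C(=O)c3ccc(N)cc3)[nH]n2)cc1` gives -35% in this assay, and compound 2 `COc1cc(-c2cc(/C=C/C(=O)c3ccc(N)cc3)[nH]n2)cc(OC)c1OC` gives -35%. Compound 3 `COc1cc(-c2cc(/C=C/C(=O)c3ccc(Cl)c(Cl)c3)[nH]n2)cc(OC)c1OC` gives -7%, which is the highest of the three numbers, beyond the scatter from both compound 1 and compound 2. Among the compounds with values here, the one single-point step that is known, a number 28 percentage points higher from compound 2 to compound 3 (beyond the scatter), shows that exchanging the 4-aminophenyl of compound 2 for a 3,4-dichlorophenyl weakened the effect in this assay.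

Compound 4 `COc1ccc(C(=O)/C=C/c2cc(-c3cc(OC)c(OC)c(OC)c3)n[nH]2)cc1` has not been measured. It differs from compound 3 at one place: 4-methoxyphenyl in place of 3,4-dichlorophenyl on a carbonyl carbon. Within the data shown here, no measured step covers the 4-methoxyphenyl directly. Among the measured compounds shown here, the only related evidence is that the 3,4-dichlorophenyl ketone of compound 3 sits at the weak end, while the 4-aminophenyl ketones of compound 1 and compound 2 sit lower; the step of a number 28 percentage points higher from compound 2 to compound 3 (beyond the scatter) is therefore the reference for how much a change at this carbonyl carbon can move the number. The 4-methoxyphenyl is neither of those groups, so a partial return toward the lower numbers, smaller than that step, is expected. For compound 4 the expected step is a number 13 percentage points lower from compound 3 to compound 4 (beyond the scatter). The estimate for compound 4 in this assay is -20%, with a range from -45% to 5%.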

Compound 4, a percentage reported as activity, at one concentration (the size of the read-out at that concentration, not a potency): -41%
Compound 4: middle estimate off by 21 percentage points, on the high side; measured number inside the range.
By their numbers in this assay, from the lowest: compounds 4, 1 and 2 (each within the scatter of the next); then compound 3.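

In this assay, a number 34 percentage points lower from compound 3 to compound 4 (beyond the scatter) shows that the low number at this carbonyl carbon does not depend on an amino-bearing ring, since the 4-methoxyphenyl also gives a large shift away from the 3,4-dichlorophenyl. The comparison with the amino compound, a number 6 percentage points lower from compound 2 to compound 4 (within the scatter), stays within the scatter, so methoxy and amino on this aromatic carbon cannot be told apart in this read-out, and of the three groups now seen on the carbonyl carbon, only the 3,4-dichlorophenyl stands apart from the others. No supporting data are available to explain why these groups on the carbonyl carbon differ.

From the compounds shown here alone, it remains open whether both chlorines are needed for the weaker effect, or whether a single chlorine would already give it, and whether a hydroxyl, a dimethylamino group or a carboxylic acid in place of the methoxy would keep the number low. Also open, going by these compounds, is whether the 3,4-dichlorophenyl moves the number by a similar amount on the core of compound 1, which carries one methoxy where compound 3 carries three.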